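From Two Fluorines to a Single Hydroxyl Group

This account rests on a few compounds, and the source may have more. Where it says the series, first, only, none or still open, it means among the compounds named here.

Among the measured compounds shown here, compound 3 `O=S(=O)(/C=C/c1ccc(F)cc1F)Cc1ccc(Nc2ncnc3ccccc23)cc1` gives 69000 nM in a functional assay on SK-OV-3 cells (Homo sapiens) (on this read-out higher numbers stand for weaker inhibition of growth and lower numbers for stronger inhibition of growth), the highest of the three numbers measured so far. Compound 2 `O=S(=O)(/C=C/c1ccc(Cl)cc1)Cc1ccc(Nc2ncnc3ccccc23)cc1` stands nearest with 54000 nM, and the step of a 1.3-fold higher number from compound 2 to compound 3 (0.11 log units; within the scatter) lies within the scatter. Compound 1 `O=S(=O)(/C=C/c1ccccc1)Cc1ccc(Nc2ncnc3ccccc23)cc1`, carrying an unsubstituted phenyl, gives 5000 nM; the step of a 14-fold higher number from compound 1 to compound 3 (1.14 log units; beyond the scatter) is large, as is an 11-fold higher number from compound 1 to compound 2 (1.03 log units; beyond the scatter).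

Compound 4 `O=S(=O)(/C=C/c1ccc(O)cc1)Cc1ccc(Nc2ncnc3ccccc23)cc1` differs from compound 3 in one place: 4-hydroxyphenyl in place of 2,4-difluorophenyl on a double-bonded chain carbon bound to a double-bonded chain carbon. For the measured compounds named here, no measured step introduces a hydroxyl group, so the bearing steps are indirect: both halogen substitutions raised the number strongly relative to compound 1, so the unsubstituted phenyl of compound 1 shows the lowest number in this set. Taking the fluorines away is therefore expected to move the number back toward that of compound 1, while the hydroxyl itself remains untested here. Compound 4 is expected at 10000 nM, with a range of 2000 nM to 60000 nM, which means an expected step of a 6.9-fold lower number from compound 3 to compound 4 (0.84 log units; beyond the scatter) toward stronger inhibition.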

Compound 4, concentration for 50% growth inhibition: 14000 nM
The estimate for compound 4 lay 1.4-fold (0.15 log units) below the measured number; the range from low to high includes it.
By their numbers in this assay, from the lowest: compound 1; then compound 4; then compounds 2 and 3 (each within the scatter of the next).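

Among the compounds shown here, with 4-hydroxyphenyl on the double-bonded chain carbon, this assay shows for the first time that this position does not treat every substituent alike: a 4.9-fold lower number from compound 3 to compound 4 (0.69 log units; beyond the scatter) and a 3.9-fold lower number from compound 2 to compound 4 (0.59 log units; beyond the scatter) both lie beyond the scatter. Hydroxy still does not match hydrogen here, as a 2.8-fold higher number from compound 1 to compound 4 (0.45 log units; beyond the scatter) leaves compound 1 with the lowest number of the four, and all three substituted phenyl groups stand above it. The data at hand give no reason for this order.

From the compounds shown here alone, whether a methoxy group, an amine or a carboxylic acid in place of the hydroxy would fall nearer compound 1 or nearer compound 2 and compound 3 remains open. Also open, going by these compounds, is how a single fluoro group would compare with the 2,4-difluorophenyl of compound 3.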